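Cytotoxicity of chalcone amides on Vero cells

The source may report more compounds than this note shows. Statements on the series, on what has been measured and on what is new or still open speak of the compounds shown alone.

Measured compounds:
compound 1 `CCOc1ccc(C(=O)/C=C/c2ccc(C(=O)Nc3cccc(-c4cc(C(=O)OC)no4)c3)cc2)cc1`: > 40 ug/mL
compound 2 `CCOC(=O)c1nnn(-c2cccc(NC(=O)c3ccc(/C=C/C(=O)c4ccc(Cl)cc4)cc3)c2)c1C`: "not determined" (no result reported)

The study measures an ADME assay on Vero cells (Chlorocebus sabaeus) for cytotoxicity, read by MTT assay, with a stated time of 72 h; on this read-out lower numbers stand for higher toxicity in this test and higher numbers for lower toxicity in this test. Compound 1 reaches only a limit of the assay in this assay, giving > 40 ug/mL. Compound 2, in this assay, carries the entry "not determined" (no result reported), so no number is available for it. Among the compounds with values here, compound 1 therefore sits at the limit of > 40 ug/mL in this assay, at which 1 of the 2 values shown sits, and no comparison between measured compounds can be drawn from these two entries.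

The unmeasured compound 3 `COC(=O)c1cc(-c2cccc(NC(=O)c3ccc(/C=C/C(=O)c4ccc([N+](=O)[O-])cc4)cc3)c2)on1` differs from compound 1 in one place: nitro in place of ethoxy on an aromatic carbon. Within the data shown here, since no step between measured compounds is known, the author has no basis for expecting a shift beyond the scatter in this assay from this change, and expects the step of a number no higher from compound 1 to compound 3 (the limit leaves the size open) to be small in either direction. It is expected that compound 3 will again lie near the limit of the assay, and the author estimates for compound 3 a value of 40 ug/mL, with a range from 20 ug/mL to 80 ug/mL, most likely reported only as a limit rather than a number.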

Compound 3, half-maximal cytotoxic concentration: > 20 ug/mL
Compound 3: a limit, no number; the forecaster's own chance of this, stated with the estimate: 70%; the middle value lies beyond the limit too.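

Compound 1 and compound 3 each stand only at a limit in this assay, so the step between them, nitro in place of ethoxy on an aromatic carbon, cannot be read. The compounds shown leave open where the true half-maximal cytotoxic concentration of either compound lies, and whether this change shifts it at all.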